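The compounds below may be only part of what the source reports. "The series", "measured", "known", "first", "only" and "open" are said of these compounds alone.

In a functional assay on cells (Homo sapiens) for antiproliferative activity, read by MTT assay, with a stated time of 48 h (a lower number here means a stronger inhibitor, a higher number a weaker inhibitor), compound 2 `CN(C)CCCn1c(N)c(-c2nc3ccccc3n2C)c2nc(C#N)c(C#N)nc21` stands at 3670 nM and compound 1 `CN(C)CCCCn1c(N)c(-c2nc3ccccc3o2)c2nc(C#N)c(C#N)nc21` at 6130 nM on the same scale, two numbers that lie within the scatter of each other, so neither can be ranked over the other. Compound 3 `CN(C)CCCCn1c(N)c(-c2nc3ccccc3n2C)c2nc(C#N)c(C#N)nc21`, not yet measured, has (dimethylamino)methyl in place of dimethylamino on a saturated chain carbon, three bonds along the chain from an aromatic nitrogen, which turns 3-(dimethylamino)propyl into 4-(dimethylamino)butyl. For the measured compounds named here, no measured pair shows this change alone. Compound 1 also carries 4-(dimethylamino)butyl and gives 6130 nM in this assay despite its different core, so no shift beyond the scatter is expected. The estimate amounts to a step of a 1.1-fold higher number from compound 2 to compound 3 (0.04 log units; within the scatter) that is expected to stay within the scatter. For compound 3 the expected value is 4000 nM with an estimated range from 1800 nM to 8500 nM for a single measurement.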

Compound 3, half-maximal inhibitory concentration: 1790 nM
Compound 3: middle estimate off by 2.2-fold (0.35 log units), on the high side; measured number below the stated range.
By their numbers in this assay, from the lowest: compound 3; then compounds 2 and 1 (each within the scatter of the next).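

For the compounds shown here, with the shared core held fixed, 4-(dimethylamino)butyl in place of 3-(dimethylamino)propyl gives a 2.1-fold lower number from compound 2 to compound 3 (0.31 log units; beyond the scatter) in this assay, so this saturated chain responds to the change, which the earlier compounds could not show. With 4-(dimethylamino)butyl held fixed, 1-methyl-1H-benzimidazol-2-yl in place of 1,3-benzoxazol-2-yl on the aromatic carbon gives a 3.4-fold lower number from compound 1 to compound 3 (0.53 log units; beyond the scatter), so the group at that carbon also counts in this assay. Both steps are modest, yet they make compound 3 the most potent of the three.

As far as these compounds go, whether a longer chain such as 5-(dimethylamino)pentyl would extend this step, or whether a pyrrolidine could replace the dimethylamino group at the chain end, remains open. Nothing available here accounts for either step.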